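Stereocentre inversion on the saturated ring of compound 2

The source may report more compounds than this note shows. Statements on the series, on what has been measured and on what is new or still open speak of the compounds shown alone.

Measured compounds in an assay on Sf9 cells for inhibition of histone deacetylase 11 (Homo sapiens), read by fluorescence, tested at 0.5 uM; a lower number here means less inhibition, a higher number more inhibition at the concentration tested (going by the name of the read-out):
- Compound 1 `O=C(NO)c1cccc(-c2cn([C@H]3C[C@H](C(=O)O)N(Cc4ccccc4)C3)nn2)c1` gives < 10%, which is a limit of the assay and not a number.
- Compound 2 `O=C(NO)c1cccc(-c2cn([C@H]3C[C@H](CO)N(Cc4ccccc4)C3)nn2)c1` gives < 10%, likewise a limit of the assay.
- Compound 3 `O=C(NO)c1ccc(-c2cn([C@@H]3C[C@@H](CO)N(CCCc4ccccc4)C3)nn2)cc1` gives 14%.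

Compound 2 stands at the limit, as does compound 1 (the limit of < 10% in this assay, at which 2 of the 3 values shown sit). Among the compounds with values here, the step that the two limits leave unreadable from compound 1 to compound 2 is therefore not readable in size, and there is no further measured step. Compound 3 sits only a little off the limit.

Compound 4 `O=C(NO)c1cccc(-c2cn([C@@H]3C[C@H](CO)N(Cc4ccccc4)C3)nn2)c1` differs from compound 2 as follows: the two compounds have the same atoms and bonds and differ only in configuration as drawn: 1 of 2 stereo elements differ; a stereocentre at a saturated ring carbon is drawn S in compound 2 and R in compound 4. No measured step changes a stereocentre on its own, so nothing among the shown compounds speaks directly to this change. Within the data shown here, the only bearing comes from compounds 1 and 2 both resting at the limit and compound 3 resting close to it, so the series as a whole shows little inhibition at this concentration.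

The step from compound 2 to compound 4 is expected to be a step that the limit leaves unreadable from compound 2 to compound 4, that is, none beyond the scatter. Compound 4 is estimated at 8%, with a range from 0% to 20%, and a limit rather than a number is considered the likelier report.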

Compound 4, a percentage reported as inhibition, at one concentration (the size of the read-out at that concentration, not a potency): < 10%
Compound 4 was reported as a limit; the forecaster's own chance of this, stated with the estimate: 60%; the middle value is on the limit's open side.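

In this assay compound 4 gives < 10%, a limit of the assay and not a number. Within the data shown here, compound 2 gives < 10%, likewise a limit, so no step from compound 2 to compound 4 can be read. As far as these compounds go, whether the configuration at this saturated ring carbon bears on inhibition stays open, since both drawn forms rest at the limit.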